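A few compounds are considered here, and "the series" means these few. Any claim that something is new, unique, unknown or untested is made for them only; others in the source may bear on it.

Compound 1 `COc1ccc2c(=O)c(/C=C/C(=O)Nc3ccc(Cl)cc3)coc2c1` is an acrylamide built on the shared core, and in a functional assay on Huh-7 cells (Homo sapiens) for inhibition, read by MTT assay, with a stated time of 48 h (on this read-out higher numbers stand for weaker inhibition and lower numbers for stronger inhibition), compound 1 gives 37100 nM. Compound 2 `O=C(/C=C/c1coc2cc(O)ccc2c1=O)NCc1ccccc1` carries a hydroxy group on the core and a benzyl amide, and in this assay compound 2 gives 4690 nM. Of the two numbers that were read, compound 1 stands highest, with compound 2 the nearest to it. Compound 3 `Cc1ccc(CNC(=O)/C=C/c2coc3cc(O)ccc3c2=O)cc1` differs from compound 2 by a methyl in place of hydrogen on an aromatic carbon, and in this assay compound 3 gives only a limit, > 100000 nM. Among the compounds with values here, the one measured step, an at least 21-fold higher number from compound 2 to compound 3 (1.32 log units; beyond the scatter), is large, showing that a small change on the aromatic part of the amide substituent can move the number far upward.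

Compound 4 `COc1ccc2c(=O)c(/C=C/C(=O)Nc3ccccc3OC)coc2c1` keeps the methoxy core of compound 1 and changes the amide substituent: 2-methoxyphenyl in place of 4-chlorophenyl on an amide-type nitrogen. Within the data shown here, no measured step touches an anilide of this kind, and compound 1 already sits at a high number, so the account expects a step of modest size, a 1.2-fold higher number from compound 1 to compound 4 (0.08 log units; within the scatter), with the upward direction somewhat favoured in view of compound 3 and its > 100000 nM. For compound 4 the estimate in this assay is 45000 nM, within a range from 12000 nM to 100000 nM.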

Compound 4, half-maximal inhibitory concentration: 32300 nM
Beside the measured number, compound 4's estimate is 1.4-fold (0.14 log units) above it; measured number inside the range.
By their numbers in this assay, from the lowest: compound 2; then compounds 4 and 1 (each within the scatter of the next). At a limit, above all of these: compound 3.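

In this assay, 2-methoxyphenyl in place of 4-chlorophenyl on an amide-type nitrogen gives a 1.1-fold lower number from compound 1 to compound 4 (0.06 log units; within the scatter), so on the methoxy core this exchange of one aromatic amide substituent for another produces no change that can be read. Within the data shown here, the one earlier step, a methyl added to the ring of the benzyl amide on the hydroxy core, was large at an at least 21-fold higher number from compound 2 to compound 3 (1.32 log units; beyond the scatter), so not every change on the aromatic part of the amide substituent moves the number far upward. Neither of the two anilides shares the limit of the assay that compound 3 alone holds: the limit of > 100000 nM in this assay, at which 1 of the 4 values shown sits.

The compounds shown leave open whether the anilide number stays this flat with an unsubstituted phenyl, or with an amine or a carboxylic acid on the ring in place of the chlorine or the methoxy group. They also leave open how one and the same amide substituent reads on the methoxy core against the hydroxy core.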